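Chlorophenyl for methylphenyl on the anilino nitrogen

The source may hold more compounds than are shown below. What is called first, only, known or untested is meant among the compounds shown, and "the series" means these compounds.

Values in an assay on isolated protein for inhibition of Polyunsaturated fatty acid 5-lipoxygenase (Homo sapiens) (on this read-out lower numbers stand for stronger inhibition and higher numbers for weaker inhibition), for the measured compounds:
compound 1 `CCOC(=O)c1c(N2CCN(c3ccccc3)CC2)[nH]c2ccc(O)cc12` gives 3100 nM
compound 2 `CCOC(=O)c1c(N2CCN(c3ccc(Cl)cc3)CC2)[nH]c2ccc(O)cc12` gives 2300 nM
compound 3 `CCOC(=O)c1c(Nc2ccc(C)cc2)[nH]c2ccc(O)cc12` gives 5000 nM

Compound 3 has the highest of the three numbers in this assay. Compound 1 sits within the scatter of it, so no order between the two can be claimed; compound 2 lies beyond the scatter, a lower number than compound 3. Among the compounds with values here, the only single-point step measured so far is a 1.3-fold lower number from compound 1 to compound 2 (0.13 log units; within the scatter), which is within the scatter.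

Compound 4 `CCOC(=O)c1c(Nc2cccc(Cl)c2)[nH]c2ccc(O)cc12` differs from compound 3 by 3-chlorophenyl in place of 4-methylphenyl on a nitrogen on an aromatic ring. Within the data shown here, the step from compound 1 to compound 2 is the one measured step that bears on it, as it also brings chlorine onto the phenyl, and it was small. Among the measured compounds shown here, no measured pair exchanges methyl for chlorine, and in compounds 1 and 2 the phenyl is linked to the core differently than in compound 3, so the transfer is loose. The expectation is therefore a step of no clear size beyond the scatter in this assay, estimated as a 1.3-fold lower number from compound 3 to compound 4 (0.10 log units; within the scatter). Compound 4 is expected to give about 4000 nM, with a range from 1500 nM to 12000 nM.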

Compound 4, half-maximal inhibitory concentration: 300 nM
For compound 4 the middle estimate is 13-fold (1.12 log units) above the measured one; the whole stated range lies above it.
By their numbers in this assay, from the lowest: compound 4; then compounds 2, 1 and 3 (each within the scatter of the next, the first and the last beyond it).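

In this assay, within the data shown here, 3-chlorophenyl in place of 4-methylphenyl on a nitrogen on an aromatic ring gives a 17-fold lower number from compound 3 to compound 4 (1.22 log units; beyond the scatter) and shows that this position can respond strongly, which the only earlier step, a 1.3-fold lower number from compound 1 to compound 2 (0.13 log units; within the scatter) and within the scatter, did not reveal. The leaving and entering groups have the same heavy-atom count and the same hydrogen-bond donor and acceptor counts, so these counts do not separate them. No supporting measurement accounts for the size of this step.

The change alters both the substituent and its place on the phenyl, and the compounds shown leave open which of the two carries the step. A 3-methylphenyl or 3-methoxyphenyl group on the same nitrogen would bear directly on that question.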